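This account rests on a few compounds, and the source may have more. Where it says the series, first, only, none or still open, it means among the compounds named here.

Compound 1 `CC1=CC[C@H](C(C)(C)NC(=S)N/N=C/c2ccccc2)CC1`: 8800 nM
Compound 2 `COc1ccc(/C=N/NC(=S)NC(C)(C)[C@H]2CC=C(C)CC2)cc1`: 8400 nM
Compound 3 `CC1=CC[C@H](C(C)(C)NC(=S)N/N=C/c2cccc(Cl)c2)CC1`: 7900 nM

In a functional assay on HT-29 cells (Homo sapiens) for inhibition, read by sulforhodamine B assay, with a stated time of 48 h (a lower number here means a stronger inhibitor of growth, a higher number a weaker inhibitor of growth), the three numbers lie within the scatter of one another; compound 3 gives the lowest of them, but that standing means little here. Compound 4 `CC1=CC[C@H](C(C)(C)NC(=S)N/N=C/c2ccc[nH]2)CC1` differs from compound 3 by 1H-pyrrol-2-yl in place of 3-chlorophenyl on a carbon with a double bond to nitrogen. Going by the values given here, the steps that bear on this change all alter the aromatic group on the same carbon: a 1.0-fold lower number from compound 1 to compound 2 (0.02 log units; within the scatter), a 1.1-fold lower number from compound 1 to compound 3 (0.05 log units; within the scatter) and a 1.1-fold lower number from compound 2 to compound 3 (0.03 log units; within the scatter). Every one of them stayed within the scatter. Among the compounds with values here, no measured step, however, exchanges the six-membered ring for a five-membered one bearing a hydrogen-bond donor, so the expectation rests on the aryl substitutions alone. Compound 4 is therefore expected to show no step beyond the scatter, a 1.1-fold higher number from compound 3 to compound 4 (0.06 log units; within the scatter), with an estimate of 9000 nM and a range from 4500 nM to 18000 nM.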

Compound 4, concentration for 50% growth inhibition: 27500 nM
Beside the measured number, compound 4's estimate is 3.1-fold (0.49 log units) below it, and the stated range ends below it.
By their numbers in this assay, from the lowest: compounds 3, 2 and 1 (each within the scatter of the next); then compound 4.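

In this assay the carbon with a double bond to nitrogen had shown no step beyond the scatter, yet 1H-pyrrol-2-yl weakens growth inhibition against all three six-membered aromatic groups (a 3.5-fold higher number from compound 3 to compound 4 (0.54 log units; beyond the scatter)) (a 3.3-fold higher number from compound 2 to compound 4 (0.52 log units; beyond the scatter)) (a 3.1-fold higher number from compound 1 to compound 4 (0.49 log units; beyond the scatter)). This place therefore does not accept every aromatic group equally, although phenyl, 4-methoxyphenyl and 3-chlorophenyl stay within the scatter of one another. Nothing available explains this step.

The five-membered ring and the hydrogen-bond donor enter together, so the compounds shown do not separate the two. A furan ring, which lacks that hydrogen, or a phenol would bear on this.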